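The compounds below may be only part of what the source reports. "The series", "measured", "known", "first", "only" and "open" are said of these compounds alone.

Measured compounds:
- Compound 1 `CCc1nncn1-c1ccc(OCc2cccc(F)c2)cc1`: in a functional assay on the whole organism (strain C57B/6) with Mus musculus as the target, in the maximal electroshock model (on this read-out lower numbers stand for an effect already at smaller amounts and higher numbers for an effect only at larger amounts of compound), compound 1 gives 22.8 mg/kg.
- Compound 2 `CCc1nncn1-c1ccc(OCc2ccc(Cl)cc2)cc1`: in this assay compound 2 gives 19.7 mg/kg.
- Compound 3 `CCc1nncn1-c1ccc(OCc2ccc(OC)cc2)cc1`: in this assay compound 3 gives 15.8 mg/kg.

Compound 2 holds the second highest of the three numbers, with compound 1 nearest and compound 3 furthest, yet all three lie within the scatter of one another, so no order among them can be read. Compound 4 `CCCOc1ccc(-n2cnnc2CC)cc1` differs from compound 2 in one place: ethyl in place of 4-chlorophenyl on a saturated chain carbon bound to an oxygen on an aromatic ring. The two measured steps, a 1.2-fold lower number from compound 1 to compound 2 (0.06 log units; within the scatter) and a 1.2-fold lower number from compound 2 to compound 3 (0.10 log units; within the scatter), only swap one small group on the benzene ring for another and leave the ring itself in place. Neither step removes the whole ring, so they bear only loosely on the change to compound 4, and they show no shift beyond the scatter. The change to compound 4 is larger than anything measured, and compound 4 is therefore expected to sit somewhat higher on this assay, a step of a 1.5-fold higher number from compound 2 to compound 4 (0.18 log units; within the scatter), with wide uncertainty. Compound 4 is estimated at 30 mg/kg, between 10 mg/kg and 90 mg/kg.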

Compound 4, dose for half-maximal effect: > 100 mg/kg
Compound 4 ended at the assay's limit (the forecaster's own chance of this, stated with the estimate: 10%); middle value at least 3.3-fold (0.52 log units) away from the limit.
By their numbers in this assay, from the lowest: compounds 3, 2 and 1 (each within the scatter of the next). At a limit, above all of these: compound 4.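

In this assay compound 4 gives > 100 mg/kg, which is a limit of the assay and not a number. Ethyl in place of 4-chlorophenyl on a saturated chain carbon bound to an oxygen on an aromatic ring is an at least 5.0-fold higher number from compound 2 to compound 4 (0.70 log units; beyond the scatter), and ethyl in place of 3-fluorophenyl is an at least 4.3-fold higher number from compound 1 to compound 4 (0.64 log units; beyond the scatter). Swapping small groups on the ring stayed within the scatter, whereas losing the whole aromatic ring at this place moves the number well beyond it, so this is the first change shown to matter.

As far as these compounds go, how far past the limit compound 4 truly lies remains unknown. From the compounds shown here alone, it is also open whether a longer chain, a cyclohexyl group or an amine at this place would return the number to the range of compounds 1, 2 and 3.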